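A Six-Membered Ring Returns in Place of Furan

The source may report more compounds than this note shows. Statements on the series, on what has been measured and on what is new or still open speak of the compounds shown alone.

Of the compounds shown here, three built on one shared core have been measured in a functional assay for inhibition, tested at 20 ug/mL; a lower number here means a weaker effect, a higher number a stronger effect of the compound at the concentration tested. Compound 1 `Cc1cc(O)c(C(C)C)cc1-c1cc(-c2ccccc2Cl)c(C#N)c(=O)[nH]1` gives 12% there. Compound 2 `Cc1cc(O)c(C(C)C)cc1-c1cc(-c2cccs2)c(C#N)c(=O)[nH]1` gives 26% in this assay. Compound 3 `Cc1cc(O)c(C(C)C)cc1-c1cc(-c2ccco2)c(C#N)c(=O)[nH]1` gives 26% in this assay. Compound 3 thus stands level with compound 2, the two together the highest of the three numbers, while compound 1 sits lowest: a number 14 percentage points higher from compound 1 to compound 3 (beyond the scatter) lies beyond the scatter, whereas no change at the digits printed from compound 2 to compound 3 (within the scatter).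

Compound 4 `COc1cccc(-c2cc(-c3cc(C(C)C)c(O)cc3C)[nH]c(=O)c2C#N)c1` is the next compound to be tested. 3-methoxyphenyl in place of furan-2-yl on an aromatic carbon

The measured step that bears on this change is a number 14 percentage points higher from compound 1 to compound 3 (beyond the scatter), in which a six-membered carbon-only ring gave way to furan-2-yl and the number rose. Compound 4 runs that exchange backwards, although the ring now entering carries 3-methoxyphenyl rather than 2-chlorophenyl, so the size is uncertain. A modest fall is therefore expected, a number 9 percentage points lower from compound 3 to compound 4 (within the scatter). Compound 4 is estimated at 17%, with a range from 5% to 32%.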

Compound 4, a percentage reported as inhibition, at one concentration (the size of the read-out at that concentration, not a potency): 22%
For compound 4 the middle estimate is 5 percentage points below the measured one; low and high end bracket the measured number.
By their numbers in this assay, from the lowest: compounds 1, 4, 2 and 3 (each within the scatter of the next, the first and the last beyond it).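

With 3-methoxyphenyl on this aromatic carbon, opposite the ring nitrogen, the shared core carries a six-membered ring of carbon only, yet the record shows a number 4 percentage points lower from compound 3 to compound 4 (within the scatter) and a number 4 percentage points lower from compound 2 to compound 4 (within the scatter) in this assay, so compound 4 cannot be told apart from either five-membered ring compound. Going by these compounds alone, the record also shows a number 10 percentage points higher from compound 1 to compound 4 (within the scatter), which means compound 4 goes against any reading of the earlier compounds as five-membered rings standing clear of six-membered ones, and that reading now rests on compound 1 alone. Nothing measured here gives a reason for these numbers.

The compounds shown do not separate the effect of ring size from that of the group the ring carries. They also do not tell how plain phenyl, or a ring bearing an amine or a carboxylic acid, would read at this position.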